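The compounds below may be only part of what the source reports. "The series", "measured", "known", "first", "only" and "open" are said of these compounds alone.

Measured so far:
- compound 1 `COC(=O)c1sc2cc(Nc3ccc(OC)cc3)cnc2c1N`: in a functional assay on A375-C5 cells (Homo sapiens) for inhibition, read by sulforhodamine B assay, with a stated time of 48 h (a higher number here means a weaker inhibitor of growth, a lower number a stronger inhibitor of growth), compound 1 gives > 150000 nM, which is a limit of the assay and not a number.
- compound 2 `COC(=O)c1sc2cc(Nc3ccc(OC)cc3OC)cnc2c1N`: in this assay compound 2 gives 27300 nM.

Compound 1 stands at the weak end of what is known in this pair. Among the compounds with values here, its value is a limit only (the limit of > 150000 nM in this assay, at which 1 of the 2 values shown sits), so no number is fixed for it, and the single measured step away from it, an at least 5.4-fold lower number from compound 1 to compound 2 (0.73 log units; beyond the scatter), is itself only a bound.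

Compound 3 `COC(=O)c1sc2cc(Nc3ccc(OC)c(OC)c3)cnc2c1N` is not yet measured. It differs from compound 1 by methoxy in place of hydrogen on an aromatic carbon. Within the data shown here, the one measured step that bears on it is the same exchange of hydrogen for methoxy on the same ring, made at another place: an at least 5.4-fold lower number from compound 1 to compound 2 (0.73 log units; beyond the scatter). Among the measured compounds shown here, no measured pair shows whether this second position carries a comparable gain. A downward step is nevertheless expected for compound 3, an at least 2.1-fold lower number from compound 1 to compound 3 (0.33 log units; beyond the scatter), smaller and less certain than the measured one. The estimate for compound 3 in this assay is 70000 nM, with a range from 25000 nM to 200000 nM, and a real chance that only a limit is returned again.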

Compound 3, concentration for 50% growth inhibition: 26300 nM
Beside the measured number, compound 3's estimate is 2.7-fold (0.43 log units) above it, within the range that was stated.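

In this assay, methoxy in place of hydrogen on an aromatic carbon ortho to a methoxy group and meta to a large group gives an at least 5.7-fold lower number from compound 1 to compound 3 (0.75 log units; beyond the scatter). Set beside an at least 5.4-fold lower number from compound 1 to compound 2 (0.73 log units; beyond the scatter), this shows that the exchange of hydrogen for methoxy lowers the number at two different places on this ring, so the effect in these compounds is not tied to a single carbon. Neither step has a fixed size, because compound 1 stands at a limit of the assay and not at a number: the limit of > 150000 nM in this assay, at which 1 of the 3 values shown sits.

Going by these compounds, the true size of the change at this position therefore stays open, as does the question of whether methoxy itself is needed here or whether a hydroxyl, an amine, a fluorine or a longer chain such as ethoxy on the same carbon would also lower the number. Also open, on these data alone, is whether a third methoxy on this ring would lower the number further, or whether changes to the methyl ester or the free amine of the shared core would alter the picture.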